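The source may report more compounds than this note shows. Statements on the series, on what has been measured and on what is new or still open speak of the compounds shown alone.

In an ADME assay on S9 fraction from liver (Rattus norvegicus) for metabolic stability, read by LC-MS, using NADPH, with a stated time of 60 min, tested at 10 uM (on this read-out lower numbers stand for a less stable compound and higher numbers for a more stable compound), compound 1 `C[C@H](O)Cc1cc(-c2ccnc3[nH]nc(C(F)(F)F)c23)cc(C2(C#N)CC2)c1` gives 37% and compound 2 `CC(C)C(O)Cc1cc(-c2ccnc3[nH]nc(C(F)(F)F)c23)cc(C2(C#N)CC2)c1` gives 19% as the lower of the two numbers. Compound 3 `CCc1cc(-c2ccnc3[nH]nc(C(F)(F)F)c23)cc(C2(C#N)CC2)c1` differs from compound 2 by methyl in place of 1-hydroxy-2-methylpropyl on a saturated chain carbon bound to an aromatic carbon with methyl in place of 1-hydroxy-2-methylpropyl on a saturated chain carbon bound to an aromatic carbon. Going by the values given here, the one measured step bearing on this is a number 18 percentage points lower from compound 1 to compound 2 (beyond the scatter) and it came with 1-hydroxy-2-methylpropyl in place of 1-hydroxyethyl, while no measured step removes the hydroxyl. A rise of similar size is expected, read as a number 21 percentage points higher from compound 2 to compound 3 (beyond the scatter) in this assay on that single step. The estimate for compound 3 is 40% with an expected range from 20% to 65% on this thin evidence.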

Compound 3, percent of the compound remaining: 78%
Beside the measured number, compound 3's estimate is 38 percentage points below it; the measured number lies above the stated range.
By their numbers in this assay, from the lowest: compound 2; then compound 1; then compound 3.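

In this assay methyl in place of 1-hydroxy-2-methylpropyl on a saturated chain carbon bound to an aromatic carbon comes with a number 59 percentage points higher from compound 2 to compound 3 (beyond the scatter) and methyl in place of 1-hydroxyethyl comes with a number 41 percentage points higher from compound 1 to compound 3 (beyond the scatter) at the same place. The earlier pair varied only the group around the hydroxyl; here, the ethyl chain without a hydroxyl stands above both hydroxylated chains. Nothing available bears on why the number rises.

Still open, on these data alone, is whether losing the hydroxyl or shortening the chain carries these steps. A longer chain without a hydroxyl, such as isobutyl, or a methyl ether of the hydroxyl would separate the two.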